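Swapping the sulfonamide amine for a hydroxypyrrolidine ring

The source may hold more compounds than are shown below. What is called first, only, known or untested is meant among the compounds shown, and "the series" means these compounds.

Measured so far in a functional assay on BXPC-3 cells (Homo sapiens) for inhibition, read by MTT assay, with a stated time of 7 days; on this read-out higher numbers stand for weaker inhibition and lower numbers for stronger inhibition:

Compound 1 `O=C([C@@H]1CCCN(S(=O)(=O)c2ccc(S(=O)(=O)C3CCC3)cc2)C1)N1CCC(F)(F)CC1`: 78 nM
Compound 2 `CCN(CC)C(=O)c1ccc(S(=O)(=O)N2CCC[C@@H](C(=O)N3CCC(F)(F)CC3)C2)cc1`: 240 nM
Compound 3 `CCN(CC)S(=O)(=O)c1ccc(S(=O)(=O)N2CCC[C@@H](C(=O)N3CCC(F)(F)CC3)C2)cc1`: 120 nM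

All three share the same core and differ only in the group attached to the aromatic ring. Compound 3 carries a diethylsulfamoyl group there and sits second highest of the three numbers in this assay: the gap to compound 1, a 1.5-fold higher number from compound 1 to compound 3 (0.19 log units; within the scatter), and the gap to compound 2, a 2.0-fold lower number from compound 2 to compound 3 (0.30 log units; within the scatter), both lie within the scatter, so the three compounds cannot be ranked with confidence.

Compound 4 `O=C([C@@H]1CCCN(S(=O)(=O)c2ccc(S(=O)(=O)N3CC[C@H](O)C3)cc2)C1)N1CCC(F)(F)CC1` changes the sulfonamide part: 3-hydroxypyrrolidin-1-yl in place of diethylamino on a sulfonyl sulfur. Among the compounds with values here, the only measured step that touches the same position is the one from cyclobutyl to diethylamino on the sulfonyl sulfur, a 1.5-fold higher number from compound 1 to compound 3 (0.19 log units; within the scatter), which stayed within the scatter. Within the data shown here, no measured step tests a hydroxyl group or a ring built into the sulfonamide, so nothing here argues for a large move in either direction in this assay. For compound 4 the expected outcome is a step of about a 1.3-fold higher number from compound 3 to compound 4 (0.10 log units; within the scatter), not beyond the scatter. Compound 4 is therefore estimated at 150 nM, within a range of 50 nM to 450 nM.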

Compound 4, half-maximal inhibitory concentration: 580 nM
For compound 4 the middle estimate is 3.9-fold (0.59 log units) below the measured one, and the stated range ends below it.
By their numbers in this assay, from the lowest: compounds 1, 3 and 2 (each within the scatter of the next, the first and the last beyond it); then compound 4.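

In this assay the group on the sulfonyl sulfur clearly matters: 3-hydroxypyrrolidin-1-yl in place of diethylamino gives a step beyond the scatter (a 4.8-fold higher number from compound 3 to compound 4 (0.68 log units; beyond the scatter)), whereas the earlier change at this sulfur stayed within it (a 1.5-fold higher number from compound 1 to compound 3 (0.19 log units; within the scatter)). The new group also compares poorly with cyclobutyl on the same sulfur (a 7.4-fold higher number from compound 1 to compound 4 (0.87 log units; beyond the scatter)), and the whole (3-hydroxypyrrolidin-1-yl)sulfonyl group compares poorly with diethylcarbamoyl on the aromatic carbon (a 2.4-fold higher number from compound 2 to compound 4 (0.38 log units; beyond the scatter)), which leaves compound 4 as the weakest inhibitor of the four in this assay. No measurement shown here bears on what lies behind this step.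

The change brings in a ring, a hydroxyl group and a defined stereocentre all at once, and the compounds shown do not tell these three apart. A plain pyrrolidin-1-yl group on the sulfonyl sulfur would test the ring without the hydroxyl group, while an open 2-hydroxyethyl chain on the sulfonamide nitrogen would test the hydroxyl group without the ring.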